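Chloro to methyl in the hydroxy amide series

The source may hold more compounds than are shown below. What is called first, only, known or untested is meant among the compounds shown, and "the series" means these compounds.

Measured so far in a functional assay on HUVEC cells (Homo sapiens) for inhibition, read by ELISA and BrdU incorporation (a higher number here means a weaker inhibitor, a lower number a stronger inhibitor), as half-maximal inhibitory concentration:
- compound 1 `Cc1ccc(C(=O)Nc2cccc3cccnc23)c(O)c1` gives 45 nM here
- compound 2 `Cc1cc(Cl)cc(C(=O)Nc2cnc3ccccc3c2)c1` gives 560 nM here
- compound 3 `O=C(Nc1cnc2ccccc2c1)c1cccc(Cl)c1O` gives 340 nM here

In this assay the number for compound 3 lies within the scatter of the number for compound 2, while compound 1 shows a clearly lower number, a gap beyond the scatter. The next compound to be measured is compound 4 `Cc1cccc(C(=O)Nc2cnc3ccccc3c2)c1O`, which carries methyl in place of chloro on an aromatic carbon, ortho to a hydroxy group and meta to a large group. Among the measured compounds shown here, no two measured compounds differ in one place only, so the data offer no direct guide to this swap. Compound 1 differs from compound 3 in more than one place, and its value is not carried over. No step beyond the scatter is expected, and the estimated step of a 1.2-fold higher number from compound 3 to compound 4 (0.07 log units; within the scatter) is small. Compound 4 is estimated at 400 nM (expected range 170 nM to 900 nM) in this assay for now.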

Compound 4, half-maximal inhibitory concentration: 780 nM
Compound 4: middle estimate off by 2.0-fold (0.29 log units), on the low side, within the range that was stated.
By their numbers in this assay, from the lowest: compound 1; then compounds 3, 2 and 4 (each within the scatter of the next, the first and the last beyond it).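

In this assay, this position ortho to a hydroxy group responds to the swap: methyl in place of chloro gives a 2.3-fold higher number from compound 3 to compound 4 (0.36 log units; beyond the scatter) as a modest step, the first in the series that can be read at a single place. Within this pair, chloro therefore gives the stronger inhibitor, though the reading rests on compound 3 and compound 4 alone. No measurement at hand accounts for the step.

From the compounds shown here alone, only chloro and methyl are seen at this position, so it remains open how fluoro, methoxy or an amine would compare there. Going by these compounds, whether the same swap gives a similar step on the core of compound 1 also remains open.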